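Chain extension of the chloroalkanamide in the shared core

The compounds below may be only part of what the source reports. "The series", "measured", "known", "first", "only" and "open" are said of these compounds alone.

Compound 1 `CCCCC(OC)c1cccc(NC(=O)NC(=O)CCl)c1`, in a functional assay on MCF7 cells (Homo sapiens) for antiproliferative activity, with a stated time of 48 h; a higher number here means a weaker inhibitor, a lower number a stronger inhibitor: 6100 nM
Compound 2 `CCCCC(OC)c1cccc(NC(=O)NC(=O)CC)c1`: compound 2 gives > 100000 nM, a limit of this assay
Compound 3 `CCCCC(OC)c1cccc(NC(=O)CCCl)c1`: compound 3 gives > 100000 nM, a limit of this assay

Compound 3 stands at the limit of this assay. That limit is the limit of > 100000 nM in this assay, at which 2 of the 3 values shown sit. The step of an at least 16-fold higher number from compound 1 to compound 3 (1.21 log units; beyond the scatter) is the only readable one that reaches compound 3; the step that the two limits leave unreadable from compound 2 to compound 3 cannot be sized, and compound 2 itself sits at the same limit. For comparison, the step of an at least 16-fold higher number from compound 1 to compound 2 (1.21 log units; beyond the scatter) was likewise large in the weaker direction.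

Compound 4 `CCCCC(OC)c1cccc(NC(=O)CCCCl)c1` differs from compound 3 by chloromethyl in place of chloro on a saturated chain carbon, two bonds along the chain from a carbonyl carbon. Among the measured compounds shown here, nothing among the measured compounds shows that lengthening this chain by one carbon recovers activity, and the nearest measured neighbour, compound 3, already lies at the limit. Compound 4 is therefore expected to remain at or near that limit, with the step that the limit leaves unreadable from compound 3 to compound 4 expected to be small or not readable. The estimate for compound 4 in this assay is 150000 nM, within 40000 nM to 600000 nM.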

Compound 4, half-maximal inhibitory concentration: > 100000 nM
Compound 4: a limit, no number; the forecaster's own chance of this, stated with the estimate: 85%; the middle value does not contradict the limit.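

Carrying the chlorine one carbon further out, as 3-chloropropyl in place of 2-chloroethyl, does not lift this chain off the limit in this assay: the limit of > 100000 nM in this assay, at which 3 of the 4 values shown sit.

Among the compounds shown here, the one readable new step is an at least 16-fold higher number from compound 1 to compound 4 (1.21 log units; beyond the scatter), so 3-chloropropyl on the carbonyl carbon, like 2-chloroethyl in compound 3, does not match the ((chloromethyl)carbonyl)amino group of compound 1. The steps from compound 2 and from compound 3 to compound 4 cannot be read, so no order among these three compounds can be given.

The compounds shown leave open whether a bromomethyl or a methoxymethyl in place of the chloromethyl of compound 1 would keep a measurable value. They also leave open whether a longer chain, such as 4-chlorobutyl, on the same carbonyl carbon would give anything other than a limit.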